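Swapping a vinyl for a dihydroxy-bearing ether on the side chain

This account rests on a few compounds, and the source may have more. Where it says the series, first, only, none or still open, it means among the compounds named here.

Compound 1, `C=CCn1cc(C(N)=S)c2c(N)ncnc21`, is measured in a functional assay on KB cells (Homo sapiens) for cytotoxicity (on this read-out higher numbers stand for weaker inhibition and lower numbers for stronger inhibition), where compound 1 gives 19000 nM. Among the numbers reported there, compound 1 has the lowest of two, but its nearest neighbour is compound 3, `NC(=S)c1c[nH]c2ncnc(N)c12`, which gives 25000 nM, and a 1.3-fold higher number from compound 1 to compound 3 (0.12 log units; within the scatter), so the two cannot be told apart. A third member of the series, compound 2, `N#Cc1cn(COCc2ccccc2)c2ncnc(N)c12`, gives > 100000 nM, which is a limit of this assay rather than a number.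

The unmeasured compound 4, `NC(=S)c1cn(COC(CO)CO)c2ncnc(N)c12`, differs from compound 1 in a single place: 2-hydroxy-1-(hydroxymethyl)ethoxy in place of vinyl on a saturated chain carbon bound to an aromatic nitrogen.

For the measured compounds named here, the only measured step that bears on this change is the one from compound 1 to compound 3, in which the group on the aromatic nitrogen was altered and the number barely moved. That step touches the same region of the molecule and suggests this part of compound 1 tolerates change without a shift beyond the scatter. Compound 2 carries a different side chain on the same nitrogen and a nitrile instead of the thioamide, so its limit cannot be tied to either change alone.

The change is therefore expected to give a step of about a 1.3-fold higher number from compound 1 to compound 4 (0.12 log units; within the scatter). Compound 4 is expected to give 25000 nM, within a range from 8000 nM to 80000 nM.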

Compound 4, half-maximal inhibitory concentration: > 100000 nM
Compound 4 was reported as a limit; the forecaster's own chance of this, stated with the estimate: 20%; at least 4.0-fold (0.60 log units) between middle value and limit.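

Replacing vinyl with 2-hydroxy-1-(hydroxymethyl)ethoxy on a saturated chain carbon bound to an aromatic nitrogen gives an at least 5.2-fold higher number from compound 1 to compound 4 (0.72 log units; beyond the scatter) in this assay, so this position does not accept every change without effect. The earlier step, a 1.3-fold higher number from compound 1 to compound 3 (0.12 log units; within the scatter), showed only that removing the whole allyl group left the number within the scatter, which made the side chain look unimportant; the new step shows that what is attached there can matter, even though having no group and having an allyl group cannot be told apart. The value of compound 4 is a limit and not a number, so the step has a lower bound but no known size, and compound 2 sits at the same limit: the limit of > 100000 nM in this assay, at which 2 of the 4 values shown sit.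

On these data alone, it stays open whether the ether oxygen, the two hydroxyl groups or the greater length of the new side chain accounts for the step, and compound 2 cannot settle this, as it also has a nitrile in place of the thioamide. A plain methoxymethyl chain, or a chain ending in an amine, on the same nitrogen of compound 1 would help separate these parts.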